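Methylquinoline in place of fluoroquinoline on the shared core

A few compounds are considered here, and "the series" means these few. Any claim that something is new, unique, unknown or untested is made for them only; others in the source may bear on it.

Compound 2 `CC(C)C1CN(C(=O)Nc2ccc(Cl)cc2)CCN1/C(=N/C#N)Nc1cccc2nc(F)ccc12` is the more stable of the two compounds measured in an ADME assay on microsomes from liver (Rattus norvegicus) for metabolic stability, with a stated time of 1 h (on this read-out lower numbers stand for a less stable compound and higher numbers for a more stable compound), where compound 2 gives 60%. Among the compounds with values here, compound 1 `CC(C)C1CN(C(=O)Nc2ccc(Cl)cc2)CCN1/C(=N/C#N)Nc1cccc2ncccc12` gives 43%; the one measured step, a number 17 percentage points higher from compound 1 to compound 2 (beyond the scatter), is a fluoro in place of hydrogen on an aromatic carbon. Compound 3 `Cc1ccc(N/C(=N\C#N)N2CCN(C(=O)Nc3ccc(Cl)cc3)CC2C(C)C)c2cccnc12` carries 8-methylquinolin-5-yl in place of 2-fluoroquinolin-5-yl on an amine nitrogen. Within the data shown here, that change undoes the fluoro step and adds a methyl for which no measured step exists, so a modest fall toward compound 1 is expected, a number 15 percentage points lower from compound 2 to compound 3 (beyond the scatter). For compound 3 the estimate is 45%, between 25% and 65%.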

Compound 3, percent of the compound remaining: 64%
Beside the measured number, compound 3's estimate is 19 percentage points below it; the measured number falls inside the stated range.
By their numbers in this assay, from the lowest: compound 1; then compounds 2 and 3 (each within the scatter of the next).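

In this assay, within the data shown here, 8-methylquinolin-5-yl on the amine nitrogen cannot be told apart from 2-fluoroquinolin-5-yl, a number 4 percentage points higher from compound 2 to compound 3 (within the scatter), so fluoro is not the only group on the shared core that goes with a higher number. The added methyl on its own goes with a number 21 percentage points higher from compound 1 to compound 3 (beyond the scatter). Nothing available speaks to the cause of either step. The compounds shown leave open whether methoxy, chloro or a longer chain such as ethyl would hold this level. They also leave open how fluoro and methyl would behave together on one quinoline.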